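Oxazole in place of thiazole: an expected half-life

The source may report more compounds than this note shows. Statements on the series, on what has been measured and on what is new or still open speak of the compounds shown alone.

Compound 1 `CC(C)(C)C(=O)OCO[P@@]1(=O)OCC(C)(C)[C@H](C(=O)NCCC(=O)OCc2cncs2)O1`: < 0.16 h
Compound 2 `COC(=O)CCNC(=O)[C@@H]1O[P@](=O)(OCOC(=O)c2scnc2C)OCC1(C)C`: < 0.16 h
Compound 3 `COC(=O)CCNC(=O)[C@@H]1O[P@@](=O)(OCOC(=O)c2scnc2C)OCC1(C)C`: > 1 h

Of the compounds shown here, three have been measured in an ADME assay on blood (Homo sapiens) for pharmacokinetics; on this read-out higher numbers stand for a longer-lived compound and lower numbers for a shorter-lived compound. Compound 1 sits at a limit of the assay, < 0.16 h, not at a number. Compound 2 likewise reaches only the limit < 0.16 h. Compound 3 stands apart: its result, > 1 h, is also a limit, but at the other end of the range, so compound 3 is the longest-lived of the three as far as the numbers show (the limit of < 0.16 h in this assay, at which 2 of the 3 values shown sit, (the limit of > 1 h in this assay, at which 1 of the 3 values shown sits)). Within the data shown here, the one step measured between neighbours, an at least 6.2-fold higher number from compound 2 to compound 3 (0.79 log units; beyond the scatter), rests on (the fact that compounds 2 and 3 differ only in the configuration as drawn).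

Compound 4 `COC(=O)CCNC(=O)[C@@H]1O[P@@](=O)(OCOC(=O)c2ocnc2C)OCC1(C)C` keeps the configuration of compound 3 and changes the ring on the ester: 4-methyl-1,3-oxazol-5-yl in place of 4-methyl-1,3-thiazol-5-yl on a carbonyl carbon. Among the measured compounds shown here, no measured step concerns this kind of ring exchange; the only step available, from compound 2 to compound 3, is one of configuration and does not bear on it. Compound 4 is therefore expected to stay close to compound 3 in this assay, with a step that the limit leaves unreadable from compound 3 to compound 4, and its estimated value is 1.5 h, in the range 0.5 h to 4 h.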

Compound 4, half-life: 0.52 h
For compound 4 the middle estimate is 2.9-fold (0.46 log units) above the measured one; the measured number falls inside the stated range.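

In this assay compound 4 gives 0.52 h, the only result among the four shown that is a number rather than a limit, so this position on the carbonyl carbon now has one exact reading. The exchange of 4-methyl-1,3-thiazol-5-yl for 4-methyl-1,3-oxazol-5-yl reads as an at least 1.9-fold lower number from compound 3 to compound 4 (0.28 log units; that floor lies within the scatter), which means the change cannot be said to exceed the usual scatter, although a larger real difference is not excluded. Compound 3 sits at a limit, > 1 h, and the true size of the step stays unknown because of that limit: the limit of > 1 h in this assay, at which 1 of the 4 values shown sits.

The compounds shown leave open how a phenyl ring or a pyridine ring would read on the same carbonyl carbon, and whether the 4-methyl group on the oxazole contributes anything to the result. Among these compounds, they also leave open whether the oxazole ester would show the same dependence on the configuration at phosphorus that separates the two thiazole esters, since the only step on that configuration concerns the thiazole pair.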